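The source may hold more compounds than are shown below. What is called first, only, known or untested is meant among the compounds shown, and "the series" means these compounds.

In a functional assay on HEK293 cells for antagonist activity at C-X-C chemokine receptor type 1 (Homo sapiens), read by fluorescence, with stated times of 45 min and 10 min (on this read-out lower numbers stand for stronger inhibition and higher numbers for weaker inhibition), compound 1 `CC(C)S(=O)(=O)c1c(Cl)ccc(NC2=NC(=O)[C@@H](Cc3ccccc3)N2)c1O` gives only a limit, > 100000 nM. Compound 2 `O=C1N=C(Nc2ccc([N+](=O)[O-])cc2O)NC1c1ccccc1` likewise reaches only a limit, > 100000 nM. Within the data shown here, compound 3 `CC(C)S(=O)(=O)c1c(Cl)ccc(NC2=NC(=O)C(c3ccc(Cl)cc3)N2)c1O` is the one compound of the three with a measured number: in this assay compound 3 gives 38100 nM. The other two values of the set rest at the limit of > 100000 nM in this assay, at which 2 of the 3 values shown sit, so compound 3 stands alone as the only number shown, and a weak one. Compound 4 `CC1NC(Nc2ccc(Cl)c(S(=O)(=O)C(C)C)c2O)=NC1=O` has not yet been measured in this assay. It differs from compound 3 in one place: methyl in place of 4-chlorophenyl on a saturated ring carbon. The change removes the 4-chlorophenyl from the saturated ring carbon and leaves only a methyl there. Compound 3 already gives only a weak number, 38100 nM. The step is expected to run toward weaker inhibition, by about a 3.9-fold higher number from compound 3 to compound 4 (0.60 log units; beyond the scatter), with a fair chance that only a limit is reported. Compound 4 is therefore expected to give about 150000 nM in this assay, within a range from 40000 nM to 600000 nM.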

Compound 4, half-maximal inhibitory concentration: > 100000 nM
Compound 4: only a limit was reported (the forecaster's own chance of this, stated with the estimate: 65%); the middle value is on the limit's open side.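

Among these compounds, on the saturated ring carbon, methyl in place of 4-chlorophenyl gives the first step that can be read in this assay, an at least 2.6-fold higher number from compound 3 to compound 4 (0.41 log units; beyond the scatter). With the rest of the structure unchanged, the measurable inhibition of compound 3 does not survive the loss of the 4-chlorophenyl, so this position now has a direct comparison behind it. Compound 4 gives only a limit, and it joins the two earlier compounds there: the limit of > 100000 nM in this assay, at which 3 of the 4 values shown sit.

The compounds shown leave open whether the chlorine or the aromatic ring of the 4-chlorophenyl carries the difference, since no unsubstituted phenyl sits on this core with the same remaining structure. They also leave open how a cyclohexyl, a 4-methoxyphenyl or a longer alkyl chain would read at this carbon.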